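Compound 3: oxan-4-yl on the pyrazole-type nitrogen

The compounds below may be only part of what the source reports. "The series", "measured", "known", "first", "only" and "open" are said of these compounds alone.

Measured in a functional assay on Ramos cells (Homo sapiens) for cytotoxicity, read by CCK-8 assay, with a stated time of 72 h; a lower number here means a stronger inhibitor, a higher number a weaker inhibitor:
- compound 1 `Cn1cc(NC(=O)c2cnc3ccc(N[C@@H]4CCCNC4)nn23)c(C(F)(F)F)n1`: > 50000 nM (a limit of the assay, not a number)
- compound 2 `Cn1cc(NC(=O)c2cnc3ccc(N[C@@H]4CCCNC4)nn23)c(C#N)n1`: 28800 nM

Compound 1 has no number of its own, only (the limit of > 50000 nM in this assay, at which 1 of the 2 values shown sits). Among the measured compounds shown here, compound 2 is the only one of the pair with a measured number, 28800 nM.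

Compound 3 `O=C(Nc1cn(C2CCOCC2)nc1C(F)(F)F)c1cnc2ccc(N[C@@H]3CCCNC3)nn12` keeps the shared core and the trifluoromethyl group of compound 1 and carries oxan-4-yl in place of methyl on an aromatic nitrogen.

For the measured compounds named here, the one measured step is an at least 1.7-fold lower number from compound 1 to compound 2 (0.23 log units; that floor lies within the scatter). That step is cyano in place of trifluoromethyl on an aromatic carbon, so it bears on this change only indirectly: it shows how little the number moved at a different place on the same ring. Going by the values given here, no measured step covers the group on the aromatic nitrogen, so the expectation is loose. In this assay no large step is expected, and compound 3 should stay in the same high range, possibly reported only as a limit.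

The estimated step is an at least 1.4-fold lower number from compound 1 to compound 3 (0.15 log units; that floor lies within the scatter). For compound 3 the expected value is 35000 nM, with an estimated range of 10000 nM to 70000 nM.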

Compound 3, half-maximal inhibitory concentration: > 50000 nM
Compound 3 was reported as a limit (the forecaster's own chance of this, stated with the estimate: 45%); middle value at least 1.4-fold (0.15 log units) away from the limit.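

No step from compound 1 to compound 3 can be read in this assay, as both compounds carry only a limit of the assay and not a number: the limit of > 50000 nM in this assay, at which 2 of the 3 values shown sit.

The compounds shown leave open whether oxan-4-yl in place of methyl on the aromatic nitrogen changes the number at all, and by how much.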